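Swapping phenoxy for chloro: an open cytotoxicity question

The source may hold more compounds than are shown below. What is called first, only, known or untested is meant among the compounds shown, and "the series" means these compounds.

Compound 1 `O=C(NCc1ccc(F)cc1)c1nc(Br)c2cccnc2c1NCCCNc1c(C(=O)NCc2ccc(F)cc2)nc(Br)c2cccnc12` gives > 20000 nM
Compound 2 `N[C@H]1CC[C@H](Nc2c(C(=O)NCc3ccc(Oc4ccccc4)cc3)nc(Br)c3cccnc23)CC1` gives "not determined" (no result reported)

In a functional assay on HCT-116 cells (Homo sapiens) for cytotoxicity, read by MTT assay, with a stated time of 72 h (on this read-out lower numbers stand for stronger inhibition and higher numbers for weaker inhibition), compound 1 gives > 20000 nM as a limit of the assay and not a number.

Compound 2 has no place on the scale: the result for compound 2 is "not determined" (no result reported) and no single number exists for it. The only reference is the limit of > 20000 nM in this assay, at which 1 of the 2 values shown sits, and that says nothing about compound 2 itself.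

Still unmeasured is compound 3 (`N[C@H]1CC[C@H](Nc2c(C(=O)NCc3ccc(Cl)cc3)nc(Br)c3cccnc23)CC1`), which differs from compound 2 in one place. The change is this: chloro in place of phenoxy on an aromatic carbon (chloro in place of phenoxy on an aromatic carbon, para to a large group).

Among the measured compounds shown here, no measured step shows what such a swap does in this assay so any forecast here is loose. The expectation is a step no larger than the usual scatter, with neither direction favoured. For compound 3 the estimated half-maximal inhibitory concentration is 3000 nM with an expected range from 500 nM to 18000 nM on repeated measurement.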

Compound 3, half-maximal inhibitory concentration: 4000 nM
Compound 3: the middle estimate sits 1.3-fold (0.12 log units) below what was measured; low and high end bracket the measured number.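

In this assay, among the compounds shown here, compound 3 gives 4000 nM while compound 2 has no reported result, and no step between these two compounds can be read. From the compounds shown here alone, whether chloro or phenoxy goes with stronger cytotoxicity on this scale stays open. Nothing shown here bears on why compound 3 gives this value.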